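A few compounds are considered here, and "the series" means these few. Any claim that something is new, unique, unknown or untested is made for them only; others in the source may bear on it.

Working notes on the series. In an assay on isolated protein for binding affinity to adenosine receptor A1 (Bos taurus) (a lower number here means a stronger inhibitor, a higher number a weaker inhibitor), compound 1 `COc1ccc(C(=O)Nc2nc(-c3ccccc3)nc3c2nnn3Cc2ccccc2F)cc1` gives 21900000 nM, and compound 2 `CC(O)CNc1nc(-c2ccccc2)nc2c1nnn2Cc1ccccc1Cl` gives 32000000 nM in this assay. These two numbers lie within the usual scatter of each other, so neither compound can be set apart from the other on this measurement; compound 1 simply holds the lower of the two numbers. Compound 3 `Fc1ccccc1Cn1nnc2c(NC3CC3)nc(-c3ccccc3)nc21` has not yet been tested in this assay. It differs from compound 1 by cyclopropyl in place of (4-methoxyphenyl)carbonyl on a nitrogen on an aromatic ring. Among the compounds with values here, no pair of measured compounds shows what a change of this kind does here, and the two values at hand give no direction to lean on. The expectation for compound 3 is therefore a step of a 1.5-fold lower number from compound 1 to compound 3 (0.16 log units; within the scatter) of no more than modest size, in either direction, and not clearly beyond the scatter. Compound 3 is estimated at 15000000 nM, with a range from 3000000 nM to 80000000 nM.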

Compound 3, inhibition constant: 15000000 nM
The estimate for compound 3 equals the measured number at the digits printed; measured number inside the range.
By their numbers in this assay, from the lowest: compounds 3, 1 and 2 (each within the scatter of the next, the first and the last beyond it).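

In this assay, within the data shown here, the first step that can be read at this position is cyclopropyl in place of (4-methoxyphenyl)carbonyl on a nitrogen on an aromatic ring, a 1.5-fold lower number from compound 1 to compound 3 (0.16 log units; within the scatter), so the exchange does not separate the two compounds. The position thus accepts a group of 3 heavy atoms with no hydrogen-bond acceptors in place of one of 10 heavy atoms with a six-membered aromatic ring, a carbonyl and 2 hydrogen-bond acceptors, with no shift beyond the scatter. No measured evidence bears on this outcome.

Still open, from the compounds shown here alone, is whether any group on this nitrogen moves the number beyond the scatter, such as a free amine, a carboxylic acid or a longer chain like n-butyl. Compound 2 differs from compound 1 and compound 3 in more than one place, so it cannot settle this.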